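Adding a Second Hydroxy to a Seven-Membered Ring Amine

A few compounds are considered here, and "the series" means these few. Any claim that something is new, unique, unknown or untested is made for them only; others in the source may bear on it.

Measured so far:
compound 1, `OC1CC(NCCCCc2ccccc2)CCc2ccccc21`, 100 nM
compound 2, `CN(CCCCc1ccccc1)C1CCc2ccccc2C(O)C1`, 66 nM
compound 3, `OC1Cc2ccccc2CCC1NCCCc1ccccc1`, 100 nM

In an assay on membranes from liver for displacement of a labelled ligand from Sigma intracellular receptor 2 (Rattus norvegicus), read by scintillation counting, with a stated time of 120 min (on this read-out higher numbers stand for weaker inhibition and lower numbers for stronger inhibition), compound 3 stands level with compound 1 at the digits shown, and the two together give the highest numbers of the three; compound 2 gives a number within the scatter of both. Among the compounds with values here, the only measured step, a 1.5-fold lower number from compound 1 to compound 2 (0.18 log units; within the scatter), concerns the amine nitrogen, not the ring.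

Compound 4, `OC1c2ccccc2CCC(NCCCc2ccccc2)C1O`, differs from compound 3 by hydroxy in place of hydrogen on a saturated ring carbon. Within the data shown here, no measured step touches a ring carbon, so nothing in the data points in either direction for this change. The number for compound 4 is therefore expected near that of compound 3, with a wide range; the estimate is 150 nM, between 40 nM and 600 nM, a step of a 1.5-fold higher number from compound 3 to compound 4 (0.18 log units; within the scatter).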

Compound 4, inhibition constant: 630 nM
The estimate for compound 4 lay 4.2-fold (0.62 log units) below the measured number, outside the stated range (above it).
By their numbers in this assay, from the lowest: compounds 2, 1 and 3 (each within the scatter of the next); then compound 4.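

In this assay hydroxy in place of hydrogen on a saturated ring carbon gives a 6.3-fold higher number from compound 3 to compound 4 (0.80 log units; beyond the scatter) and this lies beyond the scatter, the only step shown on a ring carbon. So this position of the seven-membered ring is not indifferent: a second hydroxy, next to the ring atom that bears a hydroxy group, goes with weaker inhibition. Nothing measured here explains the change. Going by these compounds, whether a methoxy group, a fluorine or an amine on this carbon would go the same way stays open. So does whether methyl on the amine nitrogen of compound 4 would shift its number.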